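The source may report more compounds than this note shows. Statements on the series, on what has been measured and on what is new or still open speak of the compounds shown alone.

Working notes on the series.

For the measured compounds named here, compound 1 `Oc1cccc(-c2cc(-c3cccc(F)c3)cc(-c3cccc(O)c3)n2)c1` is the weakest inhibitor of the three measured members: in a functional assay on T47D cells (Homo sapiens) for inhibition (on this read-out higher numbers stand for weaker inhibition and lower numbers for stronger inhibition), compound 1 gives 21300 nM, the highest number in the set. Compound 2 `Oc1cccc(-c2cc(-c3ccccc3C(F)(F)F)cc(-c3cccc(O)c3)n2)c1` gives 4350 nM in this assay, and compound 3 `Oc1cccc(-c2cc(-c3ccc(C(F)(F)F)cc3)cc(-c3cccc(O)c3)n2)c1` gives 2330 nM in this assay. The step of a 4.9-fold lower number from compound 1 to compound 2 (0.69 log units; beyond the scatter) and the step of a 9.1-fold lower number from compound 1 to compound 3 (0.96 log units; beyond the scatter) both replace the fluoro-bearing ring with a trifluoromethyl-bearing ring and both lower the number beyond the scatter, while the step of a 1.9-fold lower number from compound 2 to compound 3 (0.27 log units; within the scatter) stays within it.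

Compound 4 `Oc1cccc(-c2cc(-c3cccc(OC(F)(F)F)c3)cc(-c3cccc(O)c3)n2)c1` differs from compound 1 by trifluoromethoxy in place of fluoro on an aromatic carbon. The change keeps the substituent on the same aromatic carbon and, like the two measured steps from compound 1, exchanges a single fluorine for a larger fluorinated group. Those two steps are the only ones that bear on it; both were modest drops, so a modest drop is expected here as well, estimated as a 4.3-fold lower number from compound 1 to compound 4 (0.63 log units; beyond the scatter). Compound 4 is therefore expected to give about 5000 nM in this assay, with a range from 1500 nM to 16000 nM.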

Compound 4, half-maximal inhibitory concentration: 6740 nM
Estimate against measurement, compound 4: 1.3-fold (0.13 log units) below; the range from low to high includes it.
By their numbers in this assay, from the lowest: compounds 3, 2 and 4 (each within the scatter of the next, the first and the last beyond it); then compound 1.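

With trifluoromethoxy in place of fluoro, the substituent stays on the same aromatic carbon, meta to a large group, and this assay shows a 3.2-fold lower number from compound 1 to compound 4 (0.50 log units; beyond the scatter). Unlike the earlier steps from compound 1, this one leaves the place of substitution unchanged, so the lower number belongs to the exchange of groups at this position alone. The entering group also brings oxygen and a hydrogen-bond acceptor, and the number still falls beyond the scatter, although nothing available accounts for the drop.

The compounds shown leave open whether fluorine in the entering group matters, since every group at this position carries it. A methoxy, an amine or a carboxylic acid on the same carbon would test this, and the corresponding comparison with fluoro remains unresolved.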